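The source may report more compounds than this note shows. Statements on the series, on what has been measured and on what is new or still open speak of the compounds shown alone.

Notes on the series. In a functional assay on CHO cells for activation of 5-hydroxytryptamine receptor 1D (Homo sapiens), read by GTPgammaS binding (a higher number here means a larger maximal response, a lower number a smaller maximal response), compound 1 `CN(Cc1ccccc1)CC1CCN(CCCc2c[nH]c3ccc(-n4cnnc4)cc23)CC1` gives 93%, the highest of the three numbers in hand. Among the compounds with values here, compound 2 `OC[C@H](NC1CCN(CCCc2c[nH]c3ccc(-n4ccnc4)cc23)CC1)c1ccccc1` gives 74% and compound 3 `OC[C@H](NC1CCN(CCCc2c[nH]c3ccc(Cn4cncn4)cc23)CC1)c1ccccc1` gives 76%; the only measured step, a number 2 percentage points higher from compound 2 to compound 3 (within the scatter), changes a group on the aromatic ring and says nothing about the saturated ring carbon.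

Compound 4 `c1cc(CNC2CCN(CCCc3c[nH]c4ccc(-n5cnnc5)cc34)CC2)co1` differs from compound 1 in that place: ((furan-3-yl)methyl)amino in place of (benzyl(methyl)amino)methyl on a saturated ring carbon. Within the data shown here, no measured step covers this change, so no size can be read off directly. Among the measured compounds shown here, what the numbers do show is that compound 1, the only member without a hydrogen-bond donor on that carbon, sits beyond the scatter above compounds 2 and 3, which carry an amino group there. Compound 4 is therefore expected to fall somewhat, the step of a number 13 percentage points lower from compound 1 to compound 4 (beyond the scatter) being the estimate, without confidence that it exceeds the scatter. The expected value for compound 4 in this assay is 80%, within 65% to 95%.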

Compound 4, largest response reached (reported as efficacy), in percent of the reference or control that the assay uses: 65%
Estimate against measurement, compound 4: 15 percentage points above, and the stated range covers the measured number.
By their numbers in this assay, from the lowest: compounds 4, 2 and 3 (each within the scatter of the next, the first and the last beyond it); then compound 1.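

In this assay, the change at the saturated ring carbon, with the rest of the core of compound 1 kept, gives a number 28 percentage points lower from compound 1 to compound 4 (beyond the scatter), so the group at this position affects the maximal response. Within the data shown here, this is the first measured step at this carbon, and the earlier compounds offered no pair that isolated it. The step changes several features together: the entering ((furan-3-yl)methyl)amino group has a five-membered aromatic ring with 1 hetero atom in place of a six-membered aromatic ring of carbon only, and it has 1 hydrogen-bond donor where the leaving group has 0. No measurement in hand accounts for the step.

Going by these compounds, the separate contributions of the ring, the linking chain and the amine remain open. A benzylamino or an N-methyl-N-((furan-3-yl)methyl)amino group at this carbon would help to separate them.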